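This account rests on a few compounds, and the source may have more. Where it says the series, first, only, none or still open, it means among the compounds named here.

Measured in an ADME assay on microsomes from liver (Homo sapiens) for metabolic stability, read by LC-MS, with NADPH named in the record, with a stated time of 60 min, tested at 1 uM, in the absence of a further agent (a higher number here means that more of the compound is left, a lower number that less of the compound is left), were these compounds:

Compound 1 `COc1ccc(-c2c(C)nc3c(N4CC[C@@H](NC(=O)Nc5ccccc5)C4)cc(C)nn23)cc1OC` gives > 95% as a limit
Compound 2 `COc1ccc(-c2c(C)nc3c(N4CC[C@@H](NC(=O)OCc5ccccc5)C4)cc(C)nn23)cc1OC` gives > 95% as a limit
Compound 3 `COc1ccc(-c2c(C)nc3c(N4CC[C@@H](NC(=O)Oc5ccc6ccccc6c5)C4)cc(C)nn23)cc1OC` gives > 95% as a limit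

Compound 2 stands at > 95% as a limit of the assay and not a number. Compound 1 and compound 3 likewise report only limits. The step followed here leads to compound 4 `COc1ccc(-c2c(C)nc3c(N4CC[C@@H](NS(=O)(=O)c5ccccc5)C4)cc(C)nn23)cc1OC` and is counted as phenylsulfonyl in place of benzyloxycarbonyl on an amine nitrogen between the two structures. Among the measured compounds shown here, in words, phenylsulfonyl enters in place of benzyloxycarbonyl on an amine nitrogen, and no measured compound carries phenylsulfonyl. Three measured steps alter the group on that same amine nitrogen. For the measured compounds named here, the first is a step that the two limits leave unreadable from compound 1 to compound 2. The second is a step that the two limits leave unreadable from compound 1 to compound 3. The third is a step that the two limits leave unreadable from compound 2 to compound 3. None of them offers a size to carry over. What they leave is the limit of > 95% in this assay, at which 3 of the 3 values shown sit, and no more. With compound 2 at > 95% as a limit, no step beyond the usual scatter is expected in this assay and no direction can be named. The expected step is a number no higher from compound 2 to compound 4 (the limit leaves the size open) as an estimate only. For compound 4 the estimate is 95% with an expected range (82% to 100%).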

Compound 4, percent of the compound remaining: > 95%
Compound 4 was reported as a limit; the forecaster's own chance of this, stated with the estimate: 60%; the middle value sits exactly at the limit.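

In this assay compound 4 gives > 95%, a limit of the assay and not a number. Its steps from compound 1 and compound 2 therefore cannot be read. How phenylsulfonyl compares with the other groups on that amine nitrogen remains open, since every value stands at the same limit: the limit of > 95% in this assay, at which 4 of the 4 values shown sit.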